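Halogen swap on the anilino ring of compound 2

A few compounds are considered here, and "the series" means these few. Any claim that something is new, unique, unknown or untested is made for them only; others in the source may bear on it.

Two compounds of the series have numbers in a functional assay on NCI-H1299 cells (Homo sapiens) for antiproliferative activity, read by MTT assay, with a stated time of 72 h; on this read-out higher numbers stand for weaker inhibition and lower numbers for stronger inhibition. Compound 1 `CC(C)OC1=C(C(=O)c2ccccc2)C(c2ccc(Br)cc2)N(CCCn2ccnc2)C1=O` gives 18900 nM. Compound 2 `O=C(C1=C(Nc2ccc(Br)cc2)C(=O)N(CCCn2ccnc2)C1c1ccc(Br)cc1)c1ccccc1` gives 19300 nM. Within the data shown here, the only measured step, a 1.0-fold higher number from compound 1 to compound 2 (0.01 log units; within the scatter), exchanges the isopropoxy group on a double-bonded ring carbon for a (4-bromophenyl)amino group and leaves the number where it was. Compound 2 therefore holds the higher of the two numbers, but the two values cannot be told apart on this read-out.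

Compound 3 `O=C(C1=C(Nc2ccc(Cl)cc2)C(=O)N(CCCn2ccnc2)C1c1ccc(Br)cc1)c1ccccc1` is not yet measured. It differs from compound 2 in one place: chloro in place of bromo on an aromatic carbon. Among the measured compounds shown here, no measured step touches a halogen on this ring; the single step in hand concerns a different position and a different kind of group, so it gives no direct guidance on size or direction. With nothing in the series pointing either way, the expectation for compound 3 in this assay is a step of about a 1.0-fold lower number from compound 2 to compound 3 (0.01 log units; within the scatter), that is, none beyond the scatter. The estimate for compound 3 is 19000 nM, with a range from 8000 nM to 45000 nM.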

Compound 3, half-maximal inhibitory concentration: 25000 nM
Beside the measured number, compound 3's estimate is 1.3-fold (0.12 log units) below it; measured number inside the range.
By their numbers in this assay, from the lowest: compounds 1, 2 and 3 (each within the scatter of the next).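

Among these compounds, this is the first read on the halogen of the arylamino group: in this assay, chloro in place of bromo on an aromatic carbon, para to a large group, gives a 1.3-fold higher number from compound 2 to compound 3 (0.11 log units; within the scatter), so bromo and chloro cannot be told apart at this position. The exchange of isopropoxy on a double-bonded ring carbon now has a second example, a 1.3-fold higher number from compound 1 to compound 3 (0.12 log units; within the scatter), and neither (4-bromophenyl)amino nor (4-chlorophenyl)amino separates from isopropoxy on this read-out. No available data bear on the reason for this result.

Going by these compounds, with all three compounds within the scatter of one another, it remains open whether any change at either position can move the number beyond the scatter in this assay. A primary amine, a carboxylic acid or a methoxy group in place of the halogen would test the aromatic position more widely than a swap of one halogen for another, and a longer alkoxy chain in place of isopropoxy would do the same for the double-bonded ring carbon.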